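The source may report more compounds than this note shows. Statements on the series, on what has been measured and on what is new or still open speak of the compounds shown alone.

Compound 1 `CC(C(=O)NCc1ccc(C(F)(F)F)cc1N1CCC(C)(C)CC1)c1ccc(NS(C)(=O)=O)c(F)c1`: 1.3 nM
Compound 2 `CC(C(=O)NCc1ccc(C(F)(F)F)cc1N1CCC(c2ccc(F)cc2)CC1)c1ccc(NS(C)(=O)=O)c(F)c1`: 0.9 nM
Compound 3 `Cc1ccc(N2CCN(c3cc(C(F)(F)F)ccc3CNC(=O)C(C)c3ccc(NS(C)(=O)=O)c(F)c3)CC2)cc1`: 0.7 nM

In an assay on CHO cells for antagonist activity at transient receptor potential cation channel subfamily V member 1 (Homo sapiens), read by FLIPR (on this read-out lower numbers stand for stronger inhibition and higher numbers for weaker inhibition), compound 1 gives 1.3 nM, the highest of the three numbers, yet compound 2 at 0.9 nM and compound 3 at 0.7 nM both lie within the scatter of it, so the three cannot be ranked. Compound 4 `CCCCSc1cc(C(F)(F)F)ccc1CNC(=O)C(C)c1ccc(NS(C)(=O)=O)c(F)c1` has not been measured. It differs from compound 1 in one place: butylsulfanyl in place of 4,4-dimethylpiperidin-1-yl on an aromatic carbon. Among the measured compounds shown here, every compound measured so far carries a ring at that position, so nothing measured shows what a group with no ring does there. The step is expected to be a modest loss, a 3.1-fold higher number from compound 1 to compound 4 (0.49 log units; beyond the scatter), with wide uncertainty. Compound 4 is expected to give about 4 nM, between 1 nM and 16 nM.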

Compound 4, inhibition constant: 1.9 nM
Compound 4: middle estimate off by 2.1-fold (0.32 log units), on the high side; low and high end bracket the measured number.
By their numbers in this assay, from the lowest: compounds 3, 2, 1 and 4 (each within the scatter of the next, the first and the last beyond it).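

Replacing 4,4-dimethylpiperidin-1-yl with butylsulfanyl gives a 1.5-fold higher number from compound 1 to compound 4 (0.16 log units; within the scatter) in this assay and so shows that, in this series, a ring at this aromatic carbon is not needed for a reading in this range. Butylsulfanyl, the only group without a ring shown here, cannot be told apart from the ring it replaces. Nothing available explains why the two groups read alike. From the compounds shown here alone, whether butoxy, with oxygen in place of sulfur, or a shorter chain such as ethylsulfanyl would read the same remains open. So does the outcome with a primary amine or a carboxylic acid at this carbon.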